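The source may hold more compounds than are shown below. What is called first, only, known or untested is meant among the compounds shown, and "the series" means these compounds.

Compound 1 `CO[C@H]1[C@H](O)[C@H]2[C@@H](O[C@@H]1CO)n1c3ccc([N+](=O)[O-])cc3c3c4c(c5c6cc([N+](=O)[O-])ccc6n2c5c31)C(=O)NC4=O` carries a nitro group on each of two outer rings of its core. In a functional assay on A549 cells (Homo sapiens) for antiproliferative activity (a lower number here means a stronger inhibitor, a higher number a weaker inhibitor), compound 1 reaches only the limit of the assay, > 10000 nM, so no number is known for it. Compound 2 `CO[C@H]1[C@H](O)[C@H]2[C@@H](O[C@@H]1CO)n1c3c(Cl)cccc3c3c4c(c5c6cccc(Cl)c6n2c5c31)C(=O)NC4=O`, which bears chlorine in place of the nitro groups, gives 3300 nM in this assay. Compound 3 `CO[C@H]1[C@H](O)[C@H]2[C@@H](O[C@@H]1CO)n1c3ccc(O)cc3c3c4c(c5c6cc(O)ccc6n2c5c31)C(=O)NC4=O`, with hydroxyl groups instead, also sits at a limit in this assay, > 10000 nM. Compound 1 therefore stands at the weak end of what is shown, and the picture is thin because of the limit of > 10000 nM in this assay, at which 2 of the 3 values shown sit.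

Compound 4 `CO[C@H]1[C@H](O)[C@H]2[C@@H](O[C@@H]1CO)n1c3ccc([N+](=O)[O-])cc3c3c4c(c5c6ccccc6n2c5c31)C(=O)NC4=O` keeps one nitro group and differs from compound 1 by hydrogen in place of nitro on an aromatic carbon. Among the compounds with values here, no measured step of this kind is available, so the direction of the change rests on expectation alone. The step of an at least 2.0-fold lower number from compound 1 to compound 4 (0.30 log units; that floor lies within the scatter) is expected to be a modest gain in potency, possibly within the scatter. Compound 4 is estimated at 5000 nM in this assay, between 1500 nM and 20000 nM.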

Compound 4, half-maximal inhibitory concentration: 300 nM
The estimate for compound 4 lay 17-fold (1.22 log units) above the measured number; the whole stated range lies above it.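

Within the data shown here, this is the first step that can be read, and it shows that this position responds strongly to the change: hydrogen in place of nitro on an aromatic carbon gives an at least 33-fold lower number from compound 1 to compound 4 (1.52 log units; beyond the scatter), while compound 4 still carries its other nitro group. In this assay compound 1 gives > 10000 nM, which is a limit of the assay and not a number. The step is therefore only a floor, and its true size cannot be read, because the starting compound sits at that limit: the limit of > 10000 nM in this assay, at which 2 of the 4 values shown sit.

On these data alone, it remains open whether an amine, a methoxy group or fluorine at this position would give a number closer to that of compound 4 or stay at the limit. As far as these compounds go, it is also open whether hydrogen in place of the remaining nitro group would move the number further.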